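The source may report more compounds than this note shows. Statements on the series, on what has been measured and on what is new or still open speak of the compounds shown alone.

Working notes on the series. Compound 1 `COc1ccccc1N1C(=O)CSC1c1cc(F)cc(C(=O)O)c1` gives 8% in a functional assay on HOS cells (Homo sapiens) for inhibition, read by CCK-8 assay, with a stated time of 72 h, tested at 1 uM; on this read-out lower numbers stand for less inhibition and higher numbers for more inhibition at the one concentration tested (going by the name of the read-out). Compound 2 `O=C(NCCCCc1ccccc1)c1cccc(C2SCC(=O)N2c2cccc(F)c2)c1` gives 84% in this assay, and compound 3 `COc1cc(F)ccc1N1C(=O)CSC1c1cccc(C(=O)NCCCCc2ccccc2)c1` gives 81% in this assay. Compound 3 thus stands second highest of the three numbers, close to compound 2 and far from compound 1. Among the compounds with values here, the one measured step that alters the aryl group on the ring nitrogen is a number 3 percentage points lower from compound 2 to compound 3 (within the scatter), a change within the scatter. Compound 4 `COc1ccc(F)cc1N1C(=O)CSC1c1cccc(C(=O)NCCCCc2ccccc2)c1` differs from compound 3 by 5-fluoro-2-methoxyphenyl in place of 4-fluoro-2-methoxyphenyl on an amide-type nitrogen in a ring. Within the data shown here, the only measured step bearing on this change is small, so no step beyond the scatter is expected in this assay. Compound 4 is expected to give 78% in this assay, ranging from 64% to 89%, an expected step of a number 3 percentage points lower from compound 3 to compound 4 (within the scatter).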

Compound 4, a percentage reported as inhibition, at one concentration (the size of the read-out at that concentration, not a potency): 46%
Beside the measured number, compound 4's estimate is 32 percentage points above it, outside the stated range (below it).
By their numbers in this assay, from the lowest: compound 1; then compound 4; then compounds 3 and 2 (each within the scatter of the next).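

In this assay, the aryl group on the amide-type nitrogen in a ring is not indifferent to where its fluorine sits: 5-fluoro-2-methoxyphenyl in place of 4-fluoro-2-methoxyphenyl, with the same atoms joined differently, gives a number 35 percentage points lower from compound 3 to compound 4 (beyond the scatter) on the shared core. Methoxy in place of hydrogen on an aromatic carbon likewise gives a number 38 percentage points lower from compound 2 to compound 4 (beyond the scatter) for this pair. No measured evidence on hand accounts for either step.

On these data alone, it remains open whether ethoxy or hydroxy in place of methoxy would follow the same course. Chlorine in place of fluorine in the 5-fluoro-2-methoxyphenyl group is equally open.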